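Sulfonamide on the shortened chain, next entry in the series

The source may report more compounds than this note shows. Statements on the series, on what has been measured and on what is new or still open speak of the compounds shown alone.

Two measured compounds share one core. Compound 1 `O=C(NCCNc1nccc(-c2c(-c3cccc(F)c3)nc3sccn23)n1)c1ccc(C(F)(F)F)cc1` gives, in a functional assay on A-375 cells (Homo sapiens) for cytotoxicity, read by MTT assay (a higher number here means a weaker inhibitor, a lower number a stronger inhibitor), 8710 nM. Compound 2 `O=C(NCCCNc1nccc(-c2c(-c3cccc(F)c3)nc3sccn23)n1)c1ccc(Cl)cc1` gives in this assay 13700 nM, the higher of the two numbers, but the gap to compound 1 lies within the scatter, so no order is drawn between them. Within the data shown here, no step between the measured pair is recorded.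

Compound 3 `O=S(=O)(NCCNc1nccc(-c2c(-c3cccc(F)c3)nc3sccn23)n1)c1ccccc1` is the next entry. Against compound 2 the change is (phenylsulfonyl)amino in place of (((4-chlorophenyl)carbonyl)amino)methyl on a saturated chain carbon, two bonds along the chain from a nitrogen on an aromatic ring. Nothing measured addresses a sulfonyl group on this chain, so the expectation rests on the two values alone, which stay close to each other across a change of chain length and ring substituent. The expected step is a 1.4-fold lower number from compound 2 to compound 3 (0.14 log units; within the scatter), within the scatter and of uncertain direction. Compound 3 is estimated at 10000 nM in this assay, with a range from 3000 nM to 35000 nM.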

Compound 3, half-maximal inhibitory concentration: 11000 nM
Beside the measured number, compound 3's estimate is 1.1-fold (0.04 log units) below it; the range from low to high includes it.
By their numbers in this assay, from the lowest: compounds 1, 3 and 2 (each within the scatter of the next).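

Phenylsulfonyl in place of (4-(trifluoromethyl)phenyl)carbonyl on an amine nitrogen gives a 1.3-fold higher number from compound 1 to compound 3 (0.10 log units; within the scatter) in this assay and is the first reading of a sulfonyl link on this chain. The wider change, (phenylsulfonyl)amino in place of (((4-chlorophenyl)carbonyl)amino)methyl on a saturated chain carbon, gives a 1.2-fold lower number from compound 2 to compound 3 (0.10 log units; within the scatter) and likewise shows no readable difference. Sulfonyl and carbonyl links cannot be told apart at this place in the three compounds shown, and no other measurement bears on the result.

Open, going by these compounds, is whether a chlorine or trifluoromethyl on the phenylsulfonyl ring, or an amine or a carboxylic acid at this place, would move the number beyond the scatter. Also open, on these data alone, is how the phenylsulfonyl group reads on a longer chain.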